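This account rests on a few compounds, and the source may have more. Where it says the series, first, only, none or still open, it means among the compounds named here.

Of the compounds shown here, two of the shared core have been measured in an ADME assay on stomach for solubility, in simulated gastric fluid; a lower number here means a less soluble compound, a higher number a more soluble compound. Compound 1 `O=C(Nc1ccc(OC(F)(F)F)cc1)N1CCOC2(CCN(C(=O)c3ccccc3F)CC2)C1` gives 71 ug/mL in this assay. Compound 2 `O=C(Nc1ccc(C(F)(F)F)cc1)N1CCOC2(CCN(C(=O)c3c(F)cccc3F)CC2)C1` gives 43 ug/mL in this assay; the two numbers lie within the usual scatter of each other, so neither stands apart. Compound 3 `O=C(Nc1ccc(C(F)(F)F)cc1)N1CCOC2(CCN(C(=O)c3ccccn3)CC2)C1` is not yet measured. It differs from compound 2 in one place: pyridin-2-yl in place of 2,6-difluorophenyl on a carbonyl carbon. Going by the values given here, no measured pair shows this change, so there is no step to lean on. A modest increase in this assay is expected, a 2.1-fold higher number from compound 2 to compound 3 (0.32 log units; beyond the scatter), though a result within the scatter would not surprise. Compound 3 is estimated at 90 ug/mL, with a range from 40 ug/mL to 200 ug/mL.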

Compound 3, solubility: 85 ug/mL
Beside the measured number, compound 3's estimate is 1.1-fold (0.02 log units) above it, within the range that was stated.
By their numbers in this assay, from the lowest: compounds 2, 1 and 3 (each within the scatter of the next).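

In this assay, going by these compounds alone, pyridin-2-yl in place of 2,6-difluorophenyl on a carbonyl carbon gives a 2.0-fold higher number from compound 2 to compound 3 (0.30 log units; within the scatter), the first step that isolates this position. This single step sets a ring with one hetero atom and one hydrogen-bond acceptor against a carbon-only ring carrying two fluorines, and the two read-outs stay within the scatter. No measurement on hand accounts for the size of this step.

Open, going by these compounds, is how this assay reads when the carbonyl carbon carries a pyridine bearing an amine or a carboxylic acid. Also open, on these data alone, is whether the same change reads alike with trifluoromethoxy in place of trifluoromethyl.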